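The compounds below may be only part of what the source reports. "The series", "measured", "known", "first", "only" and "open" are said of these compounds alone.

Measured so far:
Compound 1 `O=C(CCCCCCNC(=O)C(O)(O)C(F)(F)F)Nc1c(F)cc(F)cc1F`, in a functional assay on HCT-116 cells (Homo sapiens) for inhibition, read by colorimetric assay, with a stated time of 3 days; on this read-out higher numbers stand for weaker inhibition and lower numbers for stronger inhibition: 22200 nM
Compound 2 `Cc1ccc(S(=O)(=O)Nc2ccc(NC(=O)CCCCCCNC(=O)C(O)(O)C(F)(F)F)cc2)cc1`, in this assay: 17200 nM

Compound 2 gives the lower of the two numbers in this assay, but its gap to compound 1 lies within the scatter, so the two cannot be ordered. Compound 3 `O=C(CCCCCCNC(=O)C(O)(O)C(F)(F)F)Nc1ccc(F)cc1` differs from compound 2 by fluoro in place of ((4-methylphenyl)sulfonyl)amino on an aromatic carbon. The shared core is kept, and compound 1, which also carries fluoro on its aromatic ring, gives 22200 nM in this assay. No step beyond the scatter is expected here. The expected step of a 1.4-fold higher number from compound 2 to compound 3 (0.14 log units; within the scatter) should stay within the scatter. Compound 3 is estimated at 24000 nM, with a range from 10000 nM to 60000 nM.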

Compound 3, half-maximal inhibitory concentration: 7570 nM
Compound 3: the middle estimate sits 3.2-fold (0.50 log units) above what was measured, and the stated range ends above it.
By their numbers in this assay, from the lowest: compound 3; then compounds 2 and 1 (each within the scatter of the next).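

In this assay, fluoro in place of ((4-methylphenyl)sulfonyl)amino on an aromatic carbon gives a 2.3-fold lower number from compound 2 to compound 3 (0.36 log units; beyond the scatter), so the larger group is not needed at this position for this read-out. 4-Fluorophenyl in place of 2,4,6-trifluorophenyl on the amide-type nitrogen gives a 2.9-fold lower number from compound 1 to compound 3 (0.47 log units; beyond the scatter), showing that the fluoro pattern on this ring matters, which compound 1 and compound 2 alone could not show. No available data explain either step.

On these data alone, whether chloro or methoxy in place of fluoro at this carbon, or a longer chain, would lower the number further stays open.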